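Amide substituent changes on the shared core, antiproliferative read-out

The source may hold more compounds than are shown below. What is called first, only, known or untested is meant among the compounds shown, and "the series" means these compounds.

For the measured compounds named here, compound 2 `CCn1c(C(=O)NC(C)(C)CO)ccc1C(CC)(CC)c1ccc(OCS(=O)(=O)c2ccccc2)c(C)c1` is the only member with a number in a functional assay on MCF7 cells (Homo sapiens) for antiproliferative activity, read by MTT assay, with a stated time of 24 h (on this read-out lower numbers stand for stronger inhibition and higher numbers for weaker inhibition), where compound 2 gives 20700 nM. Compound 1 `CCn1c(C(=O)N[C@H](C)C(=O)OC)ccc1C(CC)(CC)c1ccc(OCS(=O)(=O)c2ccccc2)c(C)c1` returns only a limit in this assay, > 50000 nM. Compound 3 `CCn1c(C(=O)N[C@H](C)C(=O)O)ccc1C(CC)(CC)c1ccc(OCS(=O)(=O)c2ccccc2)c(C)c1` likewise returns only a limit in this assay, > 50000 nM. The change to compound 4 `CCn1c(C(=O)NC2(C(=O)O)CC2)ccc1C(CC)(CC)c1ccc(OCS(=O)(=O)c2ccccc2)c(C)c1` is 1-carboxycyclopropyl in place of 1-(hydroxymethyl)-1-methylethyl on an amide-type nitrogen. The nearest measured step is an at least 2.4-fold higher number from compound 2 to compound 3 (0.38 log units; beyond the scatter), where a carboxylic acid also enters on the amide-type nitrogen; an at least 2.4-fold lower number from compound 1 to compound 2 (0.38 log units; beyond the scatter) runs the other way, with compound 2 the lower number. A higher number is therefore expected for compound 4, with a real chance of a limit rather than a number given (the limit of > 50000 nM in this assay, at which 2 of the 3 values shown sit). The expected step is a 2.4-fold higher number from compound 2 to compound 4 (0.38 log units; beyond the scatter). Compound 4 is estimated at 50000 nM, between 20000 nM and 150000 nM.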

Compound 4, half-maximal inhibitory concentration: 41200 nM
Beside the measured number, compound 4's estimate is 1.2-fold (0.08 log units) above it; low and high end bracket the measured number.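

Compound 4 is the only carboxylic acid shown with a number rather than a limit in this assay, and with a 2.0-fold higher number from compound 2 to compound 4 (0.30 log units; within the scatter), the 1-carboxycyclopropyl group on the amide-type nitrogen cannot be told apart from the 1-(hydroxymethyl)-1-methylethyl group. Against the other two compounds the steps are an at least 1.2-fold lower number from compound 3 to compound 4 (0.08 log units; that floor lies within the scatter) and an at least 1.2-fold lower number from compound 1 to compound 4 (0.08 log units; that floor lies within the scatter), floors that establish no difference. Both rest on a limit: the limit of > 50000 nM in this assay, at which 2 of the 4 values shown sit.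

On these data alone, what an amine or a longer alkyl chain on the amide-type nitrogen would give stays open, as does whether any such group brings the number clearly below that of compound 2.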